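A few compounds are considered here, and "the series" means these few. Any claim that something is new, unique, unknown or untested is made for them only; others in the source may bear on it.

In a functional assay on HepG2 cells (Homo sapiens) for antiproliferative activity, read by CCK-8 assay, with a stated time of 48 h (on this read-out lower numbers stand for stronger inhibition and higher numbers for weaker inhibition), compound 1 (`COc1ccc(/C=C\c2cc(OC)c(OC)c(OC)c2)cc1OCc1ccc(CN2CCCCC2C(=O)NCCNC(=O)OC(C)(C)C)cc1`) gives 1100 nM. Compound 2 (`COc1ccc(/C=C\c2cc(OC)c(OC)c(OC)c2)cc1OCc1ccc(CN2CC(C(=O)O)C2)cc1`) reads > 10000 nM, which is a limit of the assay. Compound 3 (`COc1ccc(/C=C\c2cc(OC)c(OC)c(OC)c2)cc1OCc1ccc(CN2CC[C@H](O)C2)cc1`) gives 6600 nM, the higher of the two actual numbers. Compound 4 (`COc1ccc(/C=C\c2cc(OC)c(OC)c(OC)c2)cc1OCc1ccc(CN2CCCCC2C(=O)NCCN)cc1`) is the next case, and its change from compound 3 is this: 2-((2-aminoethyl)carbamoyl)piperidin-1-yl in place of 3-hydroxypyrrolidin-1-yl on a saturated chain carbon bound to an aromatic carbon. Going by the values given here, the one measured step at that place, an at least 1.5-fold lower number from compound 2 to compound 3 (0.18 log units; that floor lies within the scatter), gives no useful size. The closer guide is compound 1 at 1100 nM, which carries the entering group capped as a tert-butyl carbamate. The expected change is a 3.7-fold lower number from compound 3 to compound 4 (0.56 log units; beyond the scatter), towards a lower number. For compound 4 the estimate is 1800 nM, with an expected range of 400 nM to 8000 nM.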

Compound 4, half-maximal inhibitory concentration: 4800 nM
For compound 4 the middle estimate is 2.7-fold (0.43 log units) below the measured one; the range from low to high includes it.
By their numbers in this assay, from the lowest: compound 1; then compounds 4 and 3 (each within the scatter of the next). At a limit, above all of these: compound 2.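

In this assay, 2-((2-aminoethyl)carbamoyl)piperidin-1-yl in place of 3-hydroxypyrrolidin-1-yl gives a 1.4-fold lower number from compound 3 to compound 4 (0.14 log units; within the scatter), so the larger group brings no measurable gain at this place. The step of an at least 2.0-fold lower number from compound 2 to compound 4 (0.31 log units; beyond the scatter) rests on a limit for compound 2: the limit of > 10000 nM in this assay, at which 1 of the 4 values shown sits. The clearer difference lies on the amine nitrogen, where hydrogen in place of tert-butoxycarbonyl gives a 4.4-fold higher number from compound 1 to compound 4 (0.64 log units; beyond the scatter), so within this pair the capped amine reads as the stronger compound.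

The compounds shown leave open whether an acetyl group or a longer alkyl chain on that nitrogen would read like tert-butoxycarbonyl or like hydrogen.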